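From hydroxy to trifluoromethyl: a small step expected

A few compounds are considered here, and "the series" means these few. Any claim that something is new, unique, unknown or untested is made for them only; others in the source may bear on it.

Measured in a functional assay on SK-BR-3 cells (Homo sapiens) for antiproliferative activity, with a stated time of 48 h; a lower number here means that less compound is needed, a higher number that more compound is needed for the effect:
- Compound 1 `Nc1ccc(NC(=O)CCCCCCC(=O)NO)cc1`: 8500 nM
- Compound 2 `O=C(CCCCCCC(=O)Nc1ccc(O)cc1)NO`: 11000 nM

Going by the values given here, the only measured step shows where compound 2 stands: a 1.3-fold higher number from compound 1 to compound 2 (0.11 log units; within the scatter). The two numbers therefore cannot be told apart.

Compound 3 `O=C(CCCCCCC(=O)Nc1ccc(C(F)(F)F)cc1)NO` keeps the core of compound 2 and changes one group: trifluoromethyl in place of hydroxy on an aromatic carbon. This is trifluoromethyl in place of hydroxy on an aromatic carbon, para to a large group.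

Among the compounds with values here, the one measured step is the only guide, since it also swaps the group at this place. It is a weak guide. Trifluoromethyl itself has not been measured on this core. No change beyond the scatter is expected in this assay, though the uncertainty is wide. The expected step is a 1.2-fold lower number from compound 2 to compound 3 (0.09 log units; within the scatter). For compound 3 the estimated value is 9000 nM, with an expected range from 3500 nM to 22000 nM.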

Compound 3, half-maximal effective concentration: 2200 nM
Compound 3: the middle estimate sits 4.1-fold (0.61 log units) above what was measured; measured number below the stated range.
By their numbers in this assay, from the lowest: compound 3; then compounds 1 and 2 (each within the scatter of the next).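

In this assay the group on the aromatic carbon para to a large group can clearly matter: trifluoromethyl gives a 5.0-fold lower number from compound 2 to compound 3 (0.70 log units; beyond the scatter) and, against amino, a 3.9-fold lower number from compound 1 to compound 3 (0.59 log units; beyond the scatter) as well. Going by these compounds alone, the earlier swap of amino for hydroxy stayed within the scatter, so this is the first change at this place to go beyond it, although both new steps are only modest. Nothing measured here accounts for the drop in the number.

From the compounds shown here alone, it remains open whether a single fluorine, a chlorine or a nitrile on the same carbon would lower the number as well, or whether trifluoromethyl stands apart. Also open, going by these compounds, is whether a longer chain on the hydroxamic acid side would add to the effect of trifluoromethyl or cancel it.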